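Adding an acetamido group to compound 1

The compounds below may be only part of what the source reports. "The series", "measured", "known", "first", "only" and "open" are said of these compounds alone.

Compound 1 `O=c1ccc(-c2ccc3cn[nH]c3c2)cn1Cc1ccccc1` gives 75 nM in an assay for inhibition of MAP kinase-interacting serine/threonine-protein kinase 2 (Homo sapiens), read by luminescence and ADP-Glo, with a stated time of 2 h (on this read-out lower numbers stand for stronger inhibition and higher numbers for weaker inhibition), the lowest of the numbers shown. Compound 2 `NC(=O)c1ccccc1Cn1cc(-c2ccc3cn[nH]c3c2)ccc1=O` has carbamoyl in place of hydrogen on an aromatic carbon and gives 340 nM, so a 4.5-fold higher number from compound 1 to compound 2 (0.66 log units; beyond the scatter). Compound 3 `Cn1ncc2ccc(-c3ccc(=O)n(Cc4ccccc4)c3)cc21` gives only a limit, > 2000 nM, which is the limit of > 2000 nM in this assay, at which 1 of the 3 values shown sits. That change, methyl in place of hydrogen on an aromatic nitrogen, brought an at least 26-fold higher number from compound 1 to compound 3 (1.42 log units; beyond the scatter). Compound 4 `CC(=O)Nc1cccc(Cn2cc(-c3ccc4cn[nH]c4c3)ccc2=O)c1` is not yet measured; it differs from compound 1 by acetamido in place of hydrogen on an aromatic carbon. For the measured compounds named here, only the step to compound 2 bears on this change, since it also adds a group on an aromatic carbon, and that step was modest. A modest weakening is therefore expected, a 2.1-fold higher number from compound 1 to compound 4 (0.33 log units; beyond the scatter). Compound 4 is estimated at 160 nM, between 50 nM and 500 nM.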

Compound 4, half-maximal inhibitory concentration: 43 nM
The estimate for compound 4 lay 3.7-fold (0.57 log units) above the measured number; the measured number lies below the stated range.
By their numbers in this assay, from the lowest: compounds 4 and 1 (each within the scatter of the next); then compound 2. At a limit, above all of these: compound 3.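

With acetamido meta to a large group, a 1.7-fold lower number from compound 1 to compound 4 (0.24 log units; within the scatter) is the step in this assay, so this added group costs nothing beyond the scatter. Adding a group to this ring therefore need not weaken inhibition, unlike carbamoyl in a 4.5-fold higher number from compound 1 to compound 2 (0.66 log units; beyond the scatter) on the same ring. Nothing shown accounts for the difference between these two steps.

Still open, as far as these compounds go, is whether a simple amine, a carboxylic acid or a longer chain at this position would match acetamido. Also unknown is how acetamido would fare on another carbon of this ring.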